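A few compounds are considered here, and "the series" means these few. Any claim that something is new, unique, unknown or untested is made for them only; others in the source may bear on it.

Working notes on the series. Compound 1 `CC1=CC[C@H](C(C)(C)NC(=S)N/N=C(\C)c2ccccc2)CC1` is the parent. In a functional assay on PC-3 cells (Homo sapiens) for inhibition, read by sulforhodamine B assay, with a stated time of 48 h (a lower number here means a stronger inhibitor of growth, a higher number a weaker inhibitor of growth), compound 1 gives only a limit of the assay, > 100000 nM, and no number. Compound 2 `COc1ccc(/C(C)=N/NC(=S)NC(C)(C)[C@H]2CC=C(C)CC2)cc1` carries a methoxy in place of hydrogen on an aromatic carbon. In this assay compound 2 likewise gives only a limit, > 100000 nM. The step that the two limits leave unreadable from compound 1 to compound 2 is therefore not readable in size, and compound 2 stands at the limit, as does the other measured value: the limit of > 100000 nM in this assay, at which 2 of the 2 values shown sit. Compound 3 `CC1=CC[C@H](C(C)(C)NC(=S)N/N=C(\C)c2ccc([N+](=O)[O-])cc2)CC1` is the next analogue, with nitro in place of methoxy on an aromatic carbon. Within the data shown here, the only measured step, from compound 1 to compound 2, bears on a change at this same aromatic position, but its size is unreadable, so no direction can be taken from it. With both measured values at the limit, compound 3 is expected also to sit near the limit, estimated at 100000 nM, within 30000 nM to 300000 nM, the expected step of a number no higher from compound 2 to compound 3 (the limit leaves the size open) meaning no movement beyond the scatter.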

Compound 3, concentration for total growth inhibition: > 100000 nM
Compound 3 was reported as a limit; the forecaster's own chance of this, stated with the estimate: 70%; the middle value lies on the limit itself.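

No step among compound 1, compound 2 and compound 3 can be read in size, since all three stand at the same limit of the assay: the limit of > 100000 nM in this assay, at which 3 of the 3 values shown sit.

The compounds shown leave open whether any change at this aromatic position gives a readable value in this assay.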